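A Second Methyl Beside the Acetamide

The compounds below may be only part of what the source reports. "The series", "measured", "known", "first", "only" and "open" are said of these compounds alone.

Among the compounds with values here, only two compounds have been measured in a functional assay on the whole organism for antagonist activity, with Mus musculus as the target, in the maximal electroshock model (a higher number here means that more compound is needed for the effect, a lower number that less compound is needed), and compound 2 `CC(=O)Nc1ccc(C(=O)Nc2c(C)cccc2C)cc1C` stands with a single neighbour, compound 1 `CC(=O)Nc1ccc(C(=O)Nc2c(C)cccc2C)cc1`, which lies within the scatter of it: compound 1 gives 3.8 mg/kg and compound 2 gives 4.5 mg/kg. The step of a 1.2-fold higher number from compound 1 to compound 2 (0.07 log units; within the scatter) therefore counts as no real movement.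

Compound 3 `CC(=O)Nc1c(C)cc(C(=O)Nc2c(C)cccc2C)cc1C` differs from compound 2 by methyl in place of hydrogen on an aromatic carbon, placed ortho to an acetamido group and meta to a methyl group. Within the data shown here, the one measured step that bears on this change is a 1.2-fold higher number from compound 1 to compound 2 (0.07 log units; within the scatter), where the same kind of substitution, the first methyl on that ring, left this assay essentially unchanged. The second methyl repeats that motion on the same ring, and nothing in the two measured compounds points to a different outcome. The expected step is therefore a 1.2-fold higher number from compound 2 to compound 3 (0.09 log units; within the scatter), no movement beyond the scatter, with a slight lean toward a higher number. The estimate for compound 3 is 5.5 mg/kg, expected to fall between 2.5 mg/kg and 12 mg/kg.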

Compound 3, dose for half-maximal effect: 170 mg/kg
The estimate for compound 3 lay 31-fold (1.49 log units) below the measured number, outside the stated range (above it).
By their numbers in this assay, from the lowest: compounds 1 and 2 (each within the scatter of the next); then compound 3.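

The same replacement of hydrogen by methyl on an aromatic carbon does not carry a fixed outcome in this assay on this ring: the first methyl gave only a step within the scatter (a 1.2-fold higher number from compound 1 to compound 2 (0.07 log units; within the scatter)), whereas the methyl ortho to an acetamido group and meta to a methyl group gave a large step beyond it (a 38-fold higher number from compound 2 to compound 3 (1.58 log units; beyond the scatter)). The two changes add the same single carbon to the same ring, so the size of the effect depends on the compound receiving the methyl, and compound 3 stands clearly apart from both compound 1 and compound 2, which remain within the scatter of each other. Nothing available accounts for this sharp rise in the dose needed, and the numbers alone give no reason for it.

The compounds shown leave open whether a single carbon is enough only when it is a methyl, or whether a chlorine, a fluorine or an ethyl group at this position would produce a comparable step. They also leave open whether the large step persists when the acetamido group of compound 3 gives way to a free amine or a longer acyl chain.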